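The compounds below may be only part of what the source reports. "The series", "measured", "known", "first", "only" and "open" are said of these compounds alone.

Measured in a functional assay on MCF7 cells (Homo sapiens) for antiproliferative activity; a higher number here means a weaker inhibitor, a lower number a stronger inhibitor:
- Compound 1 `COc1ccc(C(=O)Nc2cc3ccc(OC4CCN(C)CC4)c(C)c3oc2=O)cc1CC=C(C)C`: 1580 nM
- Compound 2 `CCCCOc1ccc(C(=O)Nc2cc3ccc(OC4CCN(C)CC4)c(C)c3oc2=O)cc1CC=C(C)C`: 1440 nM
- Compound 3 `CC(C)=CCc1cccc(C(=O)Nc2cc3ccc(OC4CCN(C)CC4)c(C)c3oc2=O)c1`: 2100 nM

These three cannot be told apart: compound 3, at 2100 nM, lies within the scatter of both others. Compound 4 `Cc1c(OC2CCN(C)CC2)ccc2cc(NC(=O)c3ccc(O)c(Cl)c3)c(=O)oc12`, not yet measured, carries 3-chloro-4-hydroxyphenyl in place of 3-(3-methylbut-2-en-1-yl)phenyl on a carbonyl carbon. The nearest evidence is indirect. Replacing methoxy or butoxy with hydrogen on an aromatic carbon gave a 1.3-fold higher number from compound 1 to compound 3 (0.12 log units; within the scatter) and a 1.5-fold higher number from compound 2 to compound 3 (0.16 log units; within the scatter), while extending the chain gave a 1.1-fold lower number from compound 1 to compound 2 (0.04 log units; within the scatter). As far as these compounds go, every measured compound keeps the 3-methylbut-2-en-1-yl group, so its loss is untested. With only these small steps as a guide, no change beyond the scatter is expected, and the expected step is a 1.4-fold higher number from compound 3 to compound 4 (0.15 log units; within the scatter). For compound 4 the estimated value is 3000 nM, with an expected range from 800 nM to 11000 nM.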

Compound 4, half-maximal inhibitory concentration: 1480 nM
Compound 4: the middle estimate sits 2.0-fold (0.31 log units) above what was measured, within the range that was stated.
By their numbers in this assay, from the lowest: compounds 2, 4, 1 and 3 (each within the scatter of the next).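

The 3-(3-methylbut-2-en-1-yl)phenyl group on the carbonyl carbon can be lost entirely: in this assay, 3-chloro-4-hydroxyphenyl in its place gives a 1.4-fold lower number from compound 3 to compound 4 (0.15 log units; within the scatter) and the result stays in the same range. This position therefore accepts a ring carrying chlorine and a hydrogen-bond donor, without the double bond outside the ring, with no change that this read-out can separate from scatter. No measured evidence accounts for this result. Still open, as far as these compounds go, is whether a ring carrying only the chlorine, only the hydroxyl, an amine or a carboxylic acid would stay in that range.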